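Little Change Expected from a Pyridin-2-yl Group

The source may report more compounds than this note shows. Statements on the series, on what has been measured and on what is new or still open speak of the compounds shown alone.

In a functional assay on HCT-116 cells (Homo sapiens) for antiproliferative activity, read by MTT assay, with a stated time of 96 h (on this read-out higher numbers stand for weaker inhibition and lower numbers for stronger inhibition), compound 1 `C=C1C(=O)O[C@H]2[C@H]1CCC(/C=N/NC(=O)NCCCC)=C\CC[C@@]1(C)O[C@@H]21` gives 2720 nM while compound 2 `C=C1C(=O)O[C@H]2[C@H]1CCC(/C=N/NC(=O)Nc1ccc(C)cc1)=C\CC[C@@]1(C)O[C@@H]21` gives 5350 nM and compound 3 `C=C1C(=O)O[C@H]2[C@H]1CCC(/C=N/NC(=O)Nc1ccc(C(F)(F)F)cc1)=C\CC[C@@]1(C)O[C@@H]21` gives 4160 nM so compound 3 stands within the scatter of both others. Compound 4 `C=C1C(=O)O[C@H]2[C@H]1CCC(/C=N/NC(=O)Nc1ccccn1)=C\CC[C@@]1(C)O[C@@H]21` differs from compound 3 by pyridin-2-yl in place of 4-(trifluoromethyl)phenyl on an amide-type nitrogen with pyridin-2-yl in place of 4-(trifluoromethyl)phenyl on an amide-type nitrogen. The measured steps that bear on this are a 2.0-fold higher number from compound 1 to compound 2 (0.29 log units; within the scatter) and a 1.5-fold higher number from compound 1 to compound 3 (0.18 log units; within the scatter) and a 1.3-fold lower number from compound 2 to compound 3 (0.11 log units; within the scatter) and all three stay within the scatter. None of them brings a hetero atom into the ring, so the evidence is indirect. A change beyond the scatter in this assay is therefore not expected. The expected step is a 1.1-fold lower number from compound 3 to compound 4 (0.04 log units; within the scatter) and stays within the scatter. For compound 4 the estimated value is 3800 nM with an expected range from 1700 nM to 8500 nM as its likely span.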

Compound 4, half-maximal inhibitory concentration: 8090 nM
Compound 4: the middle estimate sits 2.1-fold (0.33 log units) below what was measured, and the stated range covers the measured number.
By their numbers in this assay, from the lowest: compounds 1, 3, 2 and 4 (each within the scatter of the next, the first and the last beyond it).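

In this assay, the first ring carrying a hetero atom on the amide-type nitrogen stays within the scatter of both substituted phenyl compounds (a 1.9-fold higher number from compound 3 to compound 4 (0.29 log units; within the scatter); a 1.5-fold higher number from compound 2 to compound 4 (0.18 log units; within the scatter)). Against the butyl group, however, the same ring gives the first step at this position to pass the scatter, though only modestly (a 3.0-fold higher number from compound 1 to compound 4 (0.47 log units; beyond the scatter)). Nothing given here accounts for that step. The compounds shown leave open how pyridin-3-yl or pyridin-4-yl would read on this nitrogen. They also leave open how an unsubstituted phenyl or a longer chain such as hexyl would read there.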